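A Swap on the Ring Nitrogen of Compound 2

A few compounds are considered here, and "the series" means these few. Any claim that something is new, unique, unknown or untested is made for them only; others in the source may bear on it.

Of the compounds shown here, two with a shared core have been tested in a functional assay on A549 cells (Homo sapiens) for inhibition, read by MTT assay, with a stated time of 24 h; a higher number here means a weaker inhibitor, a lower number a stronger inhibitor. Compound 1 `CCOC(=O)C1=Cc2ccccc2OC1(OCc1cc(-c2ccc(F)cc2F)no1)C(F)(F)F` reaches only the limit of the assay, giving > 150000 nM. Compound 2 `CCOC(=O)C1=Cc2ccccc2OC1(OCc1cn(-c2cccc(OC)c2)nn1)C(F)(F)F` likewise reaches only a limit, giving > 150000 nM. On the numbers shown, compound 2 therefore stands at the limit of > 150000 nM in this assay, at which 2 of the 2 values shown sit, and no measured step between compounds exists to say how a single change moves this assay. Compound 3 `CCOC(=O)C1=Cc2ccccc2OC1(OCc1cn(CC(=O)Nc2ccc(C)cc2)nn1)C(F)(F)F` has not yet been measured. It differs from compound 2 in one place: ((4-methylphenyl)carbamoyl)methyl in place of 3-methoxyphenyl on an aromatic nitrogen. For the measured compounds named here, because both known values sit at the limit of > 150000 nM in this assay, at which 2 of the 2 values shown sit, there is no measured step against which to scale this change, so the expected step of a number no higher from compound 2 to compound 3 (the limit leaves the size open) is taken to be none beyond the scatter, with a strong chance that compound 3 again reports only a limit rather than a number. Compound 3 is accordingly estimated at 150000 nM in this assay, with a range from 50000 nM to 400000 nM.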

Compound 3, half-maximal inhibitory concentration: 54300 nM
Compound 3: middle estimate off by 2.8-fold (0.44 log units), on the high side, and the stated range covers the measured number.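

Of the compounds shown, compound 3 alone gives a number rather than a limit in this assay, so the group on the aromatic nitrogen of the five-membered ring is a place where a single change can move this read-out. For the compounds shown here, putting ((4-methylphenyl)carbamoyl)methyl in place of 3-methoxyphenyl gives an at least 2.7-fold lower number from compound 2 to compound 3 (0.44 log units; beyond the scatter), the first measured step in this set, and it lies beyond the usual scatter. The true size of that step remains open, and only its smallest possible size can be stated, because compound 2 reports a limit and not a number: the limit of > 150000 nM in this assay, at which 2 of the 3 values shown sit.

The change replaces the whole group at once, so the compounds shown do not separate the part played by the amide hydrogen, the carbonyl, the added methyl or the lost methoxy from one another. Nor do they show what a carboxylic acid in place of the anilide end, a methyl on the amide nitrogen or a longer chain before the carbonyl would do to the number in this assay.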